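Working notes: from compound 2 to compound 3

The compounds below may be only part of what the source reports. "The series", "measured", "known", "first", "only" and "open" are said of these compounds alone.

Measured so far:
compound 1 `Nc1scc(-c2ccc(Cl)cc2)c1C(=O)c1ccc(Cl)cc1`, 50%
compound 2 `Nc1scc(-c2ccc([N+](=O)[O-])cc2)c1C(=O)c1ccc(Cl)cc1`, 52%

In a functional assay on CHO cells for agonist activity at adenosine receptor A1 (Homo sapiens), read by fluorescence and ERK phosphorylation, with stated times of 30 min and 1.5 h, tested at 10 uM (a lower number here means a weaker effect, a higher number a stronger effect of the compound at the concentration tested), compound 2 gives 52%, the higher of the two numbers, with compound 1 nearest at 50%; the two lie within the scatter of each other. For the measured compounds named here, the one step measured, a number 2 percentage points higher from compound 1 to compound 2 (within the scatter), is within the scatter and involves nitro in place of chloro on an aromatic carbon.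

Compound 3 `COc1ccc(-c2csc(N)c2C(=O)c2ccc(Cl)cc2)cc1` is the next member, not yet measured in this assay. It differs from compound 2 as follows: methoxy in place of nitro on an aromatic carbon. Going by the values given here, no measured step covers methoxy at this position; the only step that bears on it is a number 2 percentage points higher from compound 1 to compound 2 (within the scatter), which shows that exchanging the group on this aromatic carbon left the read-out unchanged within scatter. On that basis the step of a number 2 percentage points lower from compound 2 to compound 3 (within the scatter) is expected to be none beyond the scatter. Compound 3 is therefore estimated at 50% in this assay, with a range from 30% to 68%.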

Compound 3, a percentage reported as activity, at one concentration (the size of the read-out at that concentration, not a potency): 55%
For compound 3 the middle estimate is 5 percentage points below the measured one; low and high end bracket the measured number.
By their numbers in this assay, from the lowest: compounds 1, 2 and 3 (each within the scatter of the next).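

In this assay, methoxy in place of nitro on this aromatic carbon gives a number 3 percentage points higher from compound 2 to compound 3 (within the scatter) and methoxy in place of chloro gives a number 5 percentage points higher from compound 1 to compound 3 (within the scatter) so neither step separates the two groups it compares. The place para to a large group has now carried chloro, nitro and methoxy, and the three compounds cannot be told apart at the one concentration tested. Nothing available accounts for this lack of separation at this position.

Still open, from the compounds shown here alone, is whether a different group at this place, such as an amine, a carboxylic acid or a longer alkoxy chain, would produce a step beyond the scatter. Going by these compounds, the chloro on the other aromatic ring is the same in all three compounds, so the effect of replacing it with another group, such as methoxy or an amine, also remains open.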